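The source may hold more compounds than are shown below. What is called first, only, known or untested is meant among the compounds shown, and "the series" means these compounds.

Compounds measured so far in a functional assay on CEM-DNR-bulk cells (Homo sapiens), read by MTT assay, with a stated time of 72 h; on this read-out higher numbers stand for weaker inhibition and lower numbers for stronger inhibition:
compound 1 `Cc1ncnc2c1c(I)cn2[C@@H]1O[C@H](CO)[C@@H](O)[C@H]1O`: 12600 nM
compound 2 `C#Cc1cn([C@@H]2O[C@H](CO)[C@@H](O)[C@H]2O)c2ncnc(C)c12`: 160 nM
compound 3 `C#Cc1cn([C@@H]2O[C@H](CO)[C@@H](O)[C@H]2O)c2nc(C)nc(N)c12`: 12600 nM

Compound 2 gives the lowest number of the three in this assay. Compound 1 differs from it by iodo in place of ethynyl on an aromatic carbon, and that single change made a large step, a 79-fold higher number from compound 2 to compound 1 (1.90 log units; beyond the scatter). Compound 3 carries a different core from compound 2; the difference between the two cores is not broken down here. Compound 3 stands level with compound 1 at the digits given, and these two together hold the highest numbers of the set.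

Compound 4 `Cc1nc(N)c2c(I)cn([C@@H]3O[C@H](CO)[C@@H](O)[C@H]3O)c2n1` has not yet been measured in this assay. It differs from compound 3 by iodo in place of ethynyl on an aromatic carbon, the same change that separates compound 2 from compound 1, made on the core of compound 3 rather than that of compound 2. Since compound 3 already sits at the high end of the set with 12600 nM, the earlier step gives little room to move further upward, and a step of about no change at the digits printed from compound 3 to compound 4 (within the scatter) is expected. For compound 4 the estimated value in this assay is 12600 nM, expected to lie between 5000 nM and 40000 nM.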

Compound 4, half-maximal inhibitory concentration: 3480 nM
The estimate for compound 4 lay 3.6-fold (0.56 log units) above the measured number; measured number outside the range, below it.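

In this assay, iodo in place of ethynyl on the core of compound 3 gives a 3.6-fold lower number from compound 3 to compound 4 (0.56 log units; beyond the scatter). Set beside the same change on the core of compound 2, the step does not carry over from one core to the other, either in direction or in size: the same change on two cores in this assay, a 79-fold higher number (1.90 log units; beyond the scatter) from compound 2 to compound 1 and a 3.6-fold lower number (0.56 log units; beyond the scatter) from compound 3 to compound 4, 290-fold (2.46 log units) apart, beyond the scatter of two such steps This shows that in these two pairs the outcome of the change depends on the core that carries it, but it does not show which feature of the two cores is responsible, and two pairs give no rule for predicting the step on any further core.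

The compounds shown leave open how other groups on this aromatic carbon, such as a bromo group, a nitrile or an amine, would behave on each of the two cores. They also leave open whether a longer chain ending in a triple bond would follow ethynyl or part from it on either core.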